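Butyl for Cyclopropyl on the Shared Core

A few compounds are considered here, and "the series" means these few. Any claim that something is new, unique, unknown or untested is made for them only; others in the source may bear on it.

Compound 3, `Fc1ccc(-c2nc3c(NC4CC4)cccn3c2-c2ccnc(NC3CCCC3)n2)cc1`, is the only one of the three measured compounds that yields a number in an ADME assay on Vero cells (Chlorocebus sabaeus) for cytotoxicity; on this read-out lower numbers stand for higher toxicity in this test and higher numbers for lower toxicity in this test: compound 3 gives 33000 nM. Compound 1, `C=CCOc1cccc(-c2nc3c(NC4CCCC4)cccn3c2-c2ccnc(NC3CCCC3)n2)c1`, reaches only a limit in this assay, > 40000 nM. Compound 2, `N#Cc1cccc(-c2nc3c(NC4CCCC4)cccn3c2-c2ccnc(NC3CCCC3)n2)c1`, likewise stops at a limit in this assay, > 40000 nM. The step that the two limits leave unreadable from compound 1 to compound 2 therefore cannot be read, and the limit of > 40000 nM in this assay, at which 2 of the 3 values shown sit, is all that the two limits yield. Compound 4, `CCCCNc1cccn2c(-c3ccnc(NC4CCCC4)n3)c(-c3ccc(F)cc3)nc12`, differs from compound 3 in a single place: butyl in place of cyclopropyl on a nitrogen on an aromatic ring. For the measured compounds named here, none of the measured steps touches this position, and the one step that was measured is itself unreadable, so no measured step bears on the change from compound 3 to compound 4. For this assay the change is therefore expected to remain within the usual scatter, with no direction to be read from the data. For compound 4 the step of no change at the digits printed from compound 3 to compound 4 (within the scatter) is estimated to be small. Compound 4 is accordingly expected to give 33000 nM in this assay, with an estimated range from 15000 nM to 40000 nM, the upper end reaching the region where the assay reports only a limit.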

Compound 4, half-maximal cytotoxic concentration: 32000 nM
For compound 4 the middle estimate is 1.0-fold (0.01 log units) above the measured one; the measured number falls inside the stated range.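

The exchange of cyclopropylamino for butylamino on the shared core gives a 1.0-fold lower number from compound 3 to compound 4 (0.01 log units; within the scatter) in this assay. For the compounds shown here, this is the first step that can be read as a number, and it shows that, on this read-out, a butyl chain on a nitrogen on an aromatic ring and the three-membered ring of cyclopropyl cannot be told apart. The earlier compounds could not show the size of any step, and the one step among them cannot be read: the limit of > 40000 nM in this assay, at which 2 of the 4 values shown sit.

Going by these compounds alone, with only this one pair at this place, it remains open whether a longer chain such as octyl, or a butyl chain ending in a carboxylic acid or an amine, would also stay within the scatter of compound 3 in this assay. From the compounds shown here alone, it is also open whether the same exchange would read alike on compounds carrying cyano or allyloxy on the aromatic ring in place of fluorine, and the data give no reason for the result.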